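The compounds below may be only part of what the source reports. "The series", "measured", "known", "first", "only" and "open" are said of these compounds alone.

Measured compounds:
Compound 1, `CCc1cccc(NC(=O)CSc2nc(Nc3ccccc3)c3ccccc3n2)c1`, gives 12400 nM in a functional assay on MDA-MB-231 cells (Homo sapiens) for inhibition, read by MTT assay, with a stated time of 72 h; on this read-out lower numbers stand for stronger inhibition and higher numbers for weaker inhibition.
Compound 2, `O=C(CSc1nc(Nc2ccccc2)c2ccccc2n1)Nc1ccc([N+](=O)[O-])cc1`, gives 16800 nM in this assay.

Within the data shown here, compound 2 stands at the higher of the two numbers known, and compound 1 sits close to it, since a 1.4-fold higher number from compound 1 to compound 2 (0.13 log units; within the scatter).

Compound 3, `CCc1ccc(NC(=O)CSc2nc(Nc3ccccc3)c3ccccc3n2)cc1`, is drawn from compound 2 by a single change: ethyl in place of nitro on an aromatic carbon, that is, the 4-nitrophenyl becomes 4-ethylphenyl on the amide-type nitrogen of the shared core, the new ethyl sitting para to a large group. Among the measured compounds shown here, the only measured step that bears on this is the one from compound 1 to compound 2, where a 3-ethylphenyl was exchanged for a 4-nitrophenyl, and that step stayed within the scatter. For the measured compounds named here, no measured pair separates the effect of the ethyl itself from where it sits on the ring. Compound 3 is therefore expected to land near compound 1, with a step of a 1.3-fold lower number from compound 2 to compound 3 (0.13 log units; within the scatter) that is not clearly beyond the scatter. The estimate for compound 3 in this assay is 12500 nM, in a range from 6000 nM to 28000 nM.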

Compound 3, half-maximal inhibitory concentration: 33900 nM
The estimate for compound 3 lay 2.7-fold (0.43 log units) below the measured number; measured number outside the range, above it.
By their numbers in this assay, from the lowest: compounds 1, 2 and 3 (each within the scatter of the next, the first and the last beyond it).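

In this assay the exchange of nitro for ethyl on this aromatic carbon gives a 2.0-fold higher number from compound 2 to compound 3 (0.30 log units; within the scatter) and so stays within the usual scatter, which means this change alone does not clearly separate the two compounds. The clearer signal comes from the ethyl group's place on the ring: the change from 3-ethylphenyl to 4-ethylphenyl gives a 2.7-fold higher number from compound 1 to compound 3 (0.44 log units; beyond the scatter) and is a modest step beyond the scatter, pointing to weaker inhibition with the 4-ethylphenyl. Among these compounds, then, the ethyl's place on the ring gives the only step beyond the scatter, although compound 2 lies within the scatter of both ethyl compounds.

From the compounds shown here alone, how an amine or a carboxylic acid on this aromatic carbon would compare remains open. No measurement shown here explains the gap between the two ethyl compounds.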